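The compounds below may be only part of what the source reports. "The series", "measured", "known", "first", "only" and "open" are said of these compounds alone.

Compound 1, `COc1ccc(-c2cc(-c3ccccc3)no2)c(OCCCN2CCCCC2)c1`, gives 20.8% in a functional assay on the whole organism (blood, strain Charles Foster/Wistar albino) with Rattus norvegicus as the target, with a stated time of 30 min, at a dose of 100 mg/kg by the oral route; a lower number here means less inhibition, a higher number more inhibition at the dose given (going by the name of the read-out). Compound 2, `COc1ccc(-c2cc(-c3ccccc3)no2)c(OCCCN2CCCC2)c1`, gives 21.2% in this assay. Compound 3, `CCCCN(C)CCCOc1cc(OC)ccc1-c1cc(-c2ccccc2)no1`, gives 15% in this assay.

Compound 3 holds the lowest of the three numbers, but the steps of a number 5.8 percentage points lower from compound 1 to compound 3 (within the scatter) and a number 6.2 percentage points lower from compound 2 to compound 3 (within the scatter) both lie within the scatter, as does a number 0.4 percentage points higher from compound 1 to compound 2 (within the scatter), so the three compounds cannot be put in any order on these data.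

Compound 4, `CCOC(=O)COc1cc(OC)ccc1-c1cc(-c2ccccc2)no1`, differs from compound 3 in one place: ethoxycarbonyl in place of 2-(butyl(methyl)amino)ethyl on a saturated chain carbon bound to an oxygen on an aromatic ring. Within the data shown here, none of the measured steps bears on this change directly. Among the measured compounds shown here, each of them exchanges one amine-bearing chain for another, and each stays within the scatter; no measured pair replaces the amine by an ester, so the data give no guide to the direction of this step. The only anchor is that the three measured values sit close together, and compound 3 is the starting point. On that basis the step from compound 3 to compound 4 is expected to be a number 1 percentage points higher from compound 3 to compound 4 (within the scatter), with no step beyond the scatter foreseen. Compound 4 is therefore estimated to give 16% in this assay, with a range from 4% to 30%.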

Compound 4, a percentage reported as inhibition, in the whole organism at one dose (the size of the read-out at that dose, not a potency): 10.4%
Compound 4: middle estimate off by 5.6 percentage points, on the high side; measured number inside the range.
By their numbers in this assay, from the lowest: compounds 4, 3, 1 and 2 (each within the scatter of the next, the first and the last beyond it).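

Among these compounds, replacing the amine-bearing chain with the ester gives the first steps in this set that lie beyond the scatter in this assay: a number 10.8 percentage points lower from compound 2 to compound 4 (beyond the scatter) and a number 10.4 percentage points lower from compound 1 to compound 4 (beyond the scatter), whereas the exchanges among the amines stayed within it. Compound 3 goes against any general reading of this change, since a number 4.6 percentage points lower from compound 3 to compound 4 (within the scatter) remains within the scatter, so at this position the exchange can be read as a real step only where the leaving group carries the piperidin-1-yl or pyrrolidin-1-yl ring. No measurement is available that explains these steps.

The compounds shown leave open whether the steps beyond the scatter follow from the loss of the amine or from the arrival of the ethoxycarbonyl group, a question that a carboxylic acid or a primary amide on the same saturated chain carbon could help to separate. They also leave open how a morpholine or a dimethylamino group at the end of the 3-(butyl(methyl)amino)propyl chain, or a longer chain carrying the same amines, would stand in this assay.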